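Working notes: trifluoromethyl to isopropyl step

A few compounds are considered here, and "the series" means these few. Any claim that something is new, unique, unknown or untested is made for them only; others in the source may bear on it.

Measured so far in an assay on Sf9 cells for inhibition of protein deacetylase HDAC6 (Homo sapiens), read by fluorescence, with a stated time of 40 min, tested at 100 nM; on this read-out higher numbers stand for more inhibition at the one concentration tested (going by the name of the read-out) and lower numbers for less inhibition:
compound 1, `Cc1ccc(-c2nc(CNc3ccc(C(=O)NO)cc3)n(-c3ccccc3)n2)o1`, gives 60.7%
compound 2, `O=C(NO)c1ccc(NCc2nc(-c3ccncc3)nn2-c2ccccc2)cc1`, gives 30.8%
compound 3, `O=C(NO)c1ccc(NCc2nc(-c3ccc(C(F)(F)F)cc3)nn2-c2ccccc2)cc1`, gives 41.6%

The three compounds share one core and differ only in the group attached to one aromatic carbon. Compound 3 stands second highest of the three numbers: it sits a number 10.8 percentage points higher from compound 2 to compound 3 (beyond the scatter) and a number 19.1 percentage points lower from compound 1 to compound 3 (beyond the scatter), both steps beyond the scatter but modest. The largest step in the set is a number 29.9 percentage points lower from compound 1 to compound 2 (beyond the scatter).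

Compound 4, `CC(C)c1ccc(-c2nc(CNc3ccc(C(=O)NO)cc3)n(-c3ccccc3)n2)cc1`, is the next member. Its difference from compound 3 is isopropyl in place of trifluoromethyl on an aromatic carbon. Among the compounds with values here, no measured step changes this group alone; the steps that bear on it are the swaps of the whole aryl group, a number 19.1 percentage points lower from compound 1 to compound 3 (beyond the scatter) and a number 10.8 percentage points higher from compound 2 to compound 3 (beyond the scatter), each of modest size. Within the data shown here, the isopropyl variant has no direct precedent here, so the step is expected to be small, either within the scatter or only modestly beyond it, with no firm direction.

On that basis compound 4 is expected to give about 45% in this assay, with a range from 25% to 65%. This estimate means a step of a number 3.4 percentage points higher from compound 3 to compound 4 (within the scatter), which is expected to remain within the usual scatter.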

Compound 4, a percentage reported as inhibition, at one concentration (the size of the read-out at that concentration, not a potency): 27.6%
For compound 4 the middle estimate is 17.4 percentage points above the measured one, and the stated range covers the measured number.
By their numbers in this assay, from the lowest: compounds 4 and 2 (each within the scatter of the next); then compound 3; then compound 1.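

In this assay, within the data shown here, the step from trifluoromethyl to isopropyl on the six-membered aromatic ring, para to a large group, is the first change that leaves the ring itself in place, and it gives a number 14 percentage points lower from compound 3 to compound 4 (beyond the scatter) and so shows that the read-out responds to this substituent alone and not only to swaps of the whole aryl group. The 4-isopropylphenyl and pyridin-4-yl groups give numbers that cannot be told apart, with a number 3.2 percentage points lower from compound 2 to compound 4 (within the scatter) as the printed step, so a carbon-only ring carrying isopropyl offers no separation from pyridin-4-yl in this series. Among these compounds, the 5-methylfuran-2-yl group of compound 1 keeps the highest number, beyond the scatter of all three other compounds, and a number 33.1 percentage points lower from compound 1 to compound 4 (beyond the scatter) is the only step in the set graded large.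

From the compounds shown here alone, with just two substituents compared on the phenyl ring, it remains open whether a methoxy group, an amine, a carboxylic acid or a longer alkyl chain at the same place would follow trifluoromethyl, isopropyl or neither, and whether a furan without its methyl group would hold the number of compound 1. No supporting data are available to explain the difference between trifluoromethyl and isopropyl.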